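The compounds below may be only part of what the source reports. "The series", "measured", "known", "first", "only" and "open" are said of these compounds alone.

Among the compounds with values here, compound 1 `COc1ccc2cc(C(C)c3nnc4n3N=C(c3ccc([N+](=O)[O-])cc3)CS4)ccc2c1` is one of two compounds measured in a functional assay on Huh-7 cells (Homo sapiens) for inhibition, read by sulforhodamine B assay, with a stated time of 72 h; a higher number here means a weaker inhibitor, a lower number a stronger inhibitor. In this assay compound 1 gives 14700 nM, the smaller of the two numbers shown, though the gap to the other lies within the scatter. Compound 2 `CC(C)Cc1ccc(C(C)c2n[nH]c(=S)n2N)cc1` gives 23000 nM in this assay, and the two values cannot be told apart. Within the data shown here, no step between measured compounds that differ in one place is available. Compound 3 `COc1ccc2cc(C(C)c3nnc4n3N=C(c3ccc(Cl)cc3Cl)CS4)ccc2c1` has not yet been measured in this assay. It differs from compound 1 in one place: 2,4-dichlorophenyl in place of 4-nitrophenyl on a carbon with a double bond to nitrogen. Among the measured compounds shown here, nothing among the measured compounds shows what this change does. With no basis for a direction, the step from compound 1 to compound 3 is expected to be small, a 1.2-fold lower number from compound 1 to compound 3 (0.09 log units; within the scatter), within the scatter. In this assay compound 3 is estimated at 12000 nM, in the range 5000 nM to 30000 nM.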

Compound 3, half-maximal inhibitory concentration: 10700 nM
Estimate against measurement, compound 3: 1.1-fold (0.05 log units) above; low and high end bracket the measured number.
By their numbers in this assay, from the lowest: compounds 3, 1 and 2 (each within the scatter of the next, the first and the last beyond it).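

In this assay, putting 2,4-dichlorophenyl in place of 4-nitrophenyl on the carbon with a double bond to nitrogen gives a 1.4-fold lower number from compound 1 to compound 3 (0.14 log units; within the scatter), so the two compounds cannot be told apart. Within the data shown here, this is the first reading at this position, and it shows that two differently substituted phenyl groups can sit there with no change that the assay can resolve. Nothing available speaks to the reason for this result.

From the compounds shown here alone, with only these two groups compared, it remains open whether any group at this position can move the number beyond the scatter. An amine or a carboxylic acid on the phenyl ring, an unsubstituted phenyl, or a longer chain in place of the ring could each answer that.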